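Dropping the methoxy from compound 1's aryl piperazine

A few compounds are considered here, and "the series" means these few. Any claim that something is new, unique, unknown or untested is made for them only; others in the source may bear on it.

Three compounds share a core in which a cyclic urea is tied through a chain to an aryl piperazine. In an assay on HEK293 cells for displacement of a labelled ligand from 5-hydroxytryptamine receptor 7 (Homo sapiens) (on this read-out higher numbers stand for weaker inhibition and lower numbers for stronger inhibition), compound 1 `COc1ccccc1N1CCN(CCn2c(=O)[nH]c3ccccc32)CC1` gives 1840 nM, which places it second highest of the three numbers. The nearest of the other two, compound 3 `Cc1ccccc1N1CCN(CCn2c(=O)n(-c3ccccc3C)c3ccccc32)CC1`, gives 18000 nM in this assay, and the furthest, compound 2 `O=c1[nH]c2ccccc2n1CCCCCCN1CCN(c2ccccc2)CC1`, gives 20 nM; both gaps from compound 1 are beyond the usual scatter. Compound 4 `O=c1[nH]c2ccccc2n1CCN1CCN(c2ccccc2)CC1` has not yet been measured in this assay. It differs from compound 1 in one place: hydrogen in place of methoxy on an aromatic carbon, ortho to a large group. For the measured compounds named here, no measured pair shows exactly this change, since compound 2 also carries a longer chain. Still, the low number of compound 2 in this assay, 20 nM, suggests a plain phenyl piperazine is compatible with strong binding, so a moderate step downward is expected. Compound 4 is therefore estimated at 450 nM in this assay, with a range from 120 nM to 1800 nM, an expected change of a 4.1-fold lower number from compound 1 to compound 4 (0.61 log units; beyond the scatter).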

Compound 4, inhibition constant: 1030 nM
The estimate for compound 4 lay 2.3-fold (0.36 log units) below the measured number; the range from low to high includes it.
By their numbers in this assay, from the lowest: compound 2; then compounds 4 and 1 (each within the scatter of the next); then compound 3.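

In this assay, going from 2-methoxyphenyl to phenyl gives a 1.8-fold lower number from compound 1 to compound 4 (0.25 log units; within the scatter), so on this short chain the methoxy, ortho to a large group, can go without a change that stands out from the scatter. The plain phenyl piperazine alone also does not bring the number near that of the longer-chain analogue: compound 4 gives 1030 nM and compound 2 gives 20 nM, and these two differ only in the chain. Nothing measured here speaks to why the methoxy matters so little at this place.

Going by these compounds, how a chlorine, a hydroxyl or an ethoxy would read at this place remains open. So does whether going from 2-methoxyphenyl to phenyl would read the same on the longer chain of compound 2.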